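Nitrile to tetrazole on the gem-dimethyl chain terminus

The compounds below may be only part of what the source reports. "The series", "measured", "known", "first", "only" and "open" are said of these compounds alone.

Three compounds of the series have been run in an assay on isolated protein for binding affinity to leukotriene B4 receptor 1 (Homo sapiens), tested at 1 uM; a lower number here means less inhibition, a higher number more inhibition at the concentration tested (going by the name of the read-out). Compound 1 `C=CCc1cc(C(C)=O)c(O)cc1OCCCCCCCC#N` gives 52% in this assay. Going by the values given here, compound 2 `C=CCc1cc(C(C)=O)c(O)cc1OCCCCCCCCC#N` gives 50% in this assay, and the only single-point step among the measured pair, a number 2 percentage points lower from compound 1 to compound 2 (within the scatter), is within the scatter. Compound 3 `CCc1cc(C(C)=O)c(O)cc1OCCCC(C)(C)C#N` gives 46% in this assay; its number sits within the scatter of both compound 2 and compound 1, so the three measured compounds are not separated by anything beyond the usual spread of repeats.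

The next step goes from compound 3 to compound 4 `CCc1cc(C(C)=O)c(O)cc1OCCCC(C)(C)c1nnn[nH]1`. The change is 1H-tetrazol-5-yl in place of cyano on a saturated chain carbon bound to three saturated chain carbons. Among the compounds with values here, no measured step in this assay bears on this exchange: the one step recorded, from compound 1 to compound 2, concerns a chain extension of the nitrile and not its replacement by a ring. The direction of the effect of a 1H-tetrazol-5-yl in place of cyano therefore cannot be read from the numbers in hand, and the expected step of a number 2 percentage points higher from compound 3 to compound 4 (within the scatter) is set at no change beyond the scatter, with a wide band to reflect the missing precedent. Compound 4 is accordingly estimated at 48% in this assay, within 22% to 74%.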

Compound 4, a percentage reported as inhibition, at one concentration (the size of the read-out at that concentration, not a potency): 76%
The estimate for compound 4 lay 28 percentage points below the measured number; measured number outside the range, above it.
By their numbers in this assay, from the lowest: compounds 3, 2 and 1 (each within the scatter of the next); then compound 4.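

In this assay the exchange of cyano for 1H-tetrazol-5-yl on a saturated chain carbon bound to three saturated chain carbons gives a number 30 percentage points higher from compound 3 to compound 4 (beyond the scatter) and is the first step in the series shown to clear the scatter. Going by these compounds alone, the only earlier step, a number 2 percentage points lower from compound 1 to compound 2 (within the scatter), involved a nitrile on chains of different length and stayed within the scatter, whereas this pair shows that the number responds to the identity of the group at the chain end, at least on the gem-dimethyl chain and the core of compound 3. No measurement in hand accounts for the gain, and this single pair cannot separate the contributions of the ring, its nitrogen atoms and its hydrogen-bond donor.

As far as these compounds go, whether a carboxylic acid or a primary amide on the same chain carbon would match the 1H-tetrazol-5-yl remains open. Also open, from the compounds shown here alone, is whether the gain carries over to the unbranched chains of compound 1 and compound 2, or to a chain without the gem-dimethyl carbon.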